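The source may report more compounds than this note shows. Statements on the series, on what has been measured and on what is new or still open speak of the compounds shown alone.

Measured so far:
- compound 1 `Fc1ccccc1Nc1nc2nonc2nc1Nc1cccc(F)c1F`: 500 nM
- compound 2 `Fc1ccc(Nc2nc3nonc3nc2Nc2ccccc2F)c(F)c1`: 300 nM

Among the measured compounds shown here, in an assay on mitochondria from L6 cells (Rattus norvegicus) for activation, with a stated time of 90 min (a lower number here means that less compound is needed, a higher number that more compound is needed for the effect), compound 2 holds the lower of the two numbers, but the only measured step, a 1.7-fold lower number from compound 1 to compound 2 (0.22 log units; within the scatter), stays within the scatter, so the two compounds cannot be ranked. Compound 3 `COc1cccc(Nc2nc3nonc3nc2Nc2ccccc2F)c1` differs from compound 2 by 3-methoxyphenyl in place of 2,4-difluorophenyl on a nitrogen on an aromatic ring. For the measured compounds named here, no measured step bears on this change: the one known step exchanges fluorine positions on the same phenyl, and no compound carries a methoxyphenyl here. The expected step is therefore a 1.3-fold higher number from compound 2 to compound 3 (0.12 log units; within the scatter), none beyond the scatter, with wide uncertainty. Compound 3 is expected at 400 nM, between 120 nM and 1500 nM.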

Compound 3, half-maximal effective concentration: 830 nM
Estimate against measurement, compound 3: 2.1-fold (0.32 log units) below; measured number inside the range.
By their numbers in this assay, from the lowest: compounds 2, 1 and 3 (each within the scatter of the next, the first and the last beyond it).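

In this assay, among the compounds shown here, 3-methoxyphenyl in place of 2,4-difluorophenyl on a nitrogen on an aromatic ring gives a 2.8-fold higher number from compound 2 to compound 3 (0.44 log units; beyond the scatter) and is the only step beyond the scatter, so this position is not indifferent to the group it carries. In place of 2,3-difluorophenyl, the same group gives a 1.7-fold higher number from compound 1 to compound 3 (0.22 log units; within the scatter) and leaves compound 1 and compound 3 unranked. Nothing at hand explains the step from the 2,4-difluorophenyl compound.

On these data alone, whether the higher number follows from the methoxy group or from the absence of fluorine stays open. As far as these compounds go, how a hydroxyl group, an amine or a carboxylic acid on this phenyl would read also remains unknown.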